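A few compounds are considered here, and "the series" means these few. Any claim that something is new, unique, unknown or untested is made for them only; others in the source may bear on it.

Measured in a functional assay on HT-29 cells (Homo sapiens) for inhibition, read by sulforhodamine B assay, with a stated time of 48 h; on this read-out lower numbers stand for stronger inhibition of growth and higher numbers for weaker inhibition of growth:
Compound 1 `c1cc(NC2=NCCO2)cc(OC2CCCC2)c1`: 52200 nM
Compound 2 `O=C(CCl)NC(=O)Nc1cccc(OC2CCCC2)c1`: 3100 nM

Compound 2 holds the lower of the two numbers, at 3100 nM, while compound 1 reads higher, at 52200 nM. The gap between these two numbers lies well beyond the usual scatter. The next compound, compound 3 `O=C(CCl)NC(=O)Nc1cccc(OCc2ccccc2)c1`, departs from compound 2 in one place, with benzyl in place of cyclopentyl on an oxygen on an aromatic ring. Going by the values given here, the two measured compounds differ in more than one place, so no measured step shows what such a swap does. In this assay the change is therefore expected to stay within the scatter, with no firm direction. The estimated change is a 1.1-fold lower number from compound 2 to compound 3 (0.04 log units; within the scatter). Compound 3 is expected to give about 2800 nM, with an estimated range of 900 nM to 8500 nM.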

Compound 3, concentration for 50% growth inhibition: 6500 nM
Beside the measured number, compound 3's estimate is 2.3-fold (0.37 log units) below it, within the range that was stated.
By their numbers in this assay, from the lowest: compound 2; then compound 3; then compound 1.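

In this assay the swap of benzyl in place of cyclopentyl on an oxygen on an aromatic ring gives a 2.1-fold higher number from compound 2 to compound 3 (0.32 log units; beyond the scatter) and so puts a measured size and direction on this change, a modest step beyond the scatter. It shows that the number responds to the group on this oxygen while the rest of the compound stays the same, and that, of these two groups, cyclopentyl goes with the stronger inhibition of growth. Nothing available explains why the step runs this way.

Going by these compounds alone, with only two groups compared at this oxygen, it remains open whether the trend extends to others, such as a small methyl group or a longer chain like phenethyl. It is also unknown how a carboxylic acid or an amine carried on the benzyl ring would shift the number.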